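This account rests on a few compounds, and the source may have more. Where it says the series, first, only, none or still open, it means among the compounds named here.

In a physicochemical assay for lipophilicity, read by mass spectrometry (a lower number here means a more polar compound, a higher number a more lipophilic compound), compound 1 `CCc1ccc(NC(=O)C2Cc3cc(OC)c(OC)cc3C2=O)cc1` gives 3.11, compound 2 `COc1cc2c(cc1OC)C(=O)C(C(=O)Nc1ccc(Cl)cc1)C2` gives 2.76 and compound 3 `COc1cc2c(cc1OC)C(=O)C(C(=O)Nc1ccc(Br)cc1)C2` gives 3.03. Compound 1 thus stands with compound 3 at the upper end of these numbers, the step being a number 0.08 log units lower from compound 1 to compound 3 (within the scatter). Compound 4 `COc1cc2c(cc1OC)C(=O)C(C(=O)Nc1cccc(Cl)c1)C2` differs from compound 1 as follows: 3-chlorophenyl in place of 4-ethylphenyl on an amide-type nitrogen. The closest measured precedent is chloro in place of ethyl, a number 0.35 log units lower from compound 1 to compound 2 (beyond the scatter). Among the compounds with values here, no measured compound shows what the 3-chlorophenyl placement does by itself. A modest fall in this assay is therefore expected, the estimated step being a number 0.31 log units lower from compound 1 to compound 4 (beyond the scatter). Compound 4 is estimated at 2.8, with an expected range of 2.5 to 3.1.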

Compound 4, partition coefficient: 2.76
Beside the measured number, compound 4's estimate is 0.04 log units above it; the measured number falls inside the stated range.
By their numbers in this assay, from the lowest: compounds 2, 4, 3 and 1 (each within the scatter of the next, the first and the last beyond it).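

Within the data shown here, on the amide-type nitrogen, this assay does not separate 3-chlorophenyl from 4-chlorophenyl, showing no change at the digits printed from compound 2 to compound 4 (within the scatter) and so giving the first reading of this placement. Against 4-bromophenyl, 3-chlorophenyl gives a number 0.27 log units lower from compound 3 to compound 4 (within the scatter) and against 4-ethylphenyl it gives a number 0.35 log units lower from compound 1 to compound 4 (beyond the scatter) which matches in size a number 0.35 log units lower from compound 1 to compound 2 (beyond the scatter) and so ties the fall to the change of group, with the placement adding nothing visible. Nothing at hand explains these numbers. Still open, from the compounds shown here alone, is whether 3-bromophenyl would track 3-chlorophenyl, and where a phenyl carrying an amine or a carboxylic acid would fall in this assay on this nitrogen.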